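The compounds below may be only part of what the source reports. "The series", "measured", "known", "first", "only" and "open" are said of these compounds alone.

Measured compounds:
- compound 1, `CCn1cc(C(=O)O)c(=O)c2cc(F)c(N3CCN(CN4C(=O)/C(=N\NC(=S)NO)c5cc(C)ccc54)C(C)C3)c(F)c21`: 244000 nM
- compound 2, `CONC(=S)N/N=C1\C(=O)N(CN2CCN(c3ccc(OC)cc3)CC2)c2ccc(C)cc21`: 324000 nM
- compound 3, `COc1ccc(N2CCN(CN3C(=O)/C(=N\NC(=S)NO)c4cc(C)ccc43)CC2)cc1`: 321000 nM

All three were measured in an ADME assay on MT4 cells (Homo sapiens) for cytotoxicity, read by spectrophotometry, with a stated time of 5 days; on this read-out lower numbers stand for higher toxicity in this test and higher numbers for lower toxicity in this test. The change from compound 3 to compound 2 is methyl in place of hydrogen on an oxygen and gave a 1.0-fold higher number from compound 3 to compound 2 (0.00 log units; within the scatter). Compound 1 carries a different core from compound 3; the difference between the two cores is not broken down here, and the values of compound 1 and compound 3 lie within the scatter of each other.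

Compound 4, `CCn1cc(C(=O)O)c(=O)c2cc(F)c(N3CCN(CN4C(=O)/C(=N\NC(=S)NOC)c5cc(C)ccc54)C(C)C3)c(F)c21`, is not yet measured. It arises from compound 1 by methyl in place of hydrogen on an oxygen, the same change as from compound 3 to compound 2, at the same place. Because that earlier change gave a 1.0-fold higher number from compound 3 to compound 2 (0.00 log units; within the scatter), the step of a 1.0-fold higher number from compound 1 to compound 4 (0.01 log units; within the scatter) is expected in this assay, with compound 1 as the anchor. Compound 4 is estimated at 250000 nM, between 140000 nM and 450000 nM.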

Compound 4, half-maximal cytotoxic concentration: 156000 nM
Estimate against measurement, compound 4: 1.6-fold (0.20 log units) above; measured number inside the range.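

In this assay, hydroxy to methoxy on the core of compound 1 gave a 1.6-fold lower number from compound 1 to compound 4 (0.19 log units; within the scatter). Set beside the same change on the other core, the two steps do not differ: the same change on two cores in this assay, a 1.0-fold higher number (0.00 log units; within the scatter) from compound 3 to compound 2 and a 1.6-fold lower number (0.19 log units; within the scatter) from compound 1 to compound 4, 1.6-fold (0.20 log units) apart, within the scatter of two such steps. Among these compounds, in this test the change therefore carries from one of these cores to the other without a visible gap, but with only two pairs, and neither step beyond the scatter, this does not show that the change moves the number on either core, nor how it would behave on a further core.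

Still open, going by these compounds, is whether a longer chain on that oxygen, such as ethyl or propyl, would give a step beyond the scatter. The same holds for an amine in place of the methoxyamino group.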